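The compounds below may be only part of what the source reports. "The series", "measured", "known", "first", "only" and "open" are said of these compounds alone.

Measured so far:
Compound 1, `N#CNC(=N)Nc1cccnc1`, gives 50 mg/kg in a functional assay on the whole organism (blood, strain Wistar-Okamoto) with Rattus norvegicus as the target, with a stated time of 5 days; on this read-out lower numbers stand for an effect already at smaller amounts and higher numbers for an effect only at larger amounts of compound.
Compound 2, `C/N=C(\NC#N)Nc1cccnc1`, reaches only a limit of this assay, > 50 mg/kg, and not a number.
Compound 3, `CCC/N=C(\NC#N)Nc1cccnc1`, gives 20 mg/kg in this assay.

Compound 3 holds the lowest of the two numbers; compound 1 sits higher, beyond the scatter. Compound 4, `CCCC/N=C(\NC#N)Nc1cccnc1`, differs from compound 3 by methyl in place of hydrogen on a saturated chain carbon, three bonds along the chain from a double-bonded nitrogen. Going by the values given here, the one measured step that bears on this change is the chain lengthening an at least 2.5-fold lower number from compound 2 to compound 3 (0.39 log units; beyond the scatter), whose full size is hidden by the limit of > 50 mg/kg in this assay, at which 1 of the 3 values shown sits. One further carbon on the chain is therefore expected to give a small step lower in this assay, or none beyond the scatter. Compound 4 is estimated at 15 mg/kg, between 5 mg/kg and 50 mg/kg, an expected step of a 1.3-fold lower number from compound 3 to compound 4 (0.12 log units; within the scatter).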

Compound 4, minimum effective dose: 20 mg/kg
For compound 4 the middle estimate is 1.3-fold (0.12 log units) below the measured one; the measured number falls inside the stated range.
By their numbers in this assay, from the lowest: compounds 3 and 4 (each within the scatter of the next); then compound 1.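

Going by these compounds alone, with no change at the digits printed from compound 3 to compound 4 (within the scatter) in this assay, the methyl added three bonds along the chain from a double-bonded nitrogen shows what the earlier compounds could not: the step seen on lengthening the chain does not continue at this carbon. Set against compound 2, the butyl chain of compound 4 gives an at least 2.5-fold lower number from compound 2 to compound 4 (0.39 log units; beyond the scatter), and the full size of that step stays hidden: the limit of > 50 mg/kg in this assay, at which 1 of the 4 values shown sits.

On these data alone, whether a longer chain such as hexyl would leave the number in the same place remains open. So does the effect of an amine or a carboxylic acid at the chain end.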